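This account rests on a few compounds, and the source may have more. Where it says the series, first, only, none or still open, it means among the compounds named here.

Measured compounds:
- compound 1, `CC(=O)N1N=C(c2ccc(-n3ccnc3)cc2)CC1c1ccc(N(C)C)cc1`, in a functional assay on HCC1806 cells (Homo sapiens) for inhibition, read by sulforhodamine B assay, tested at 10 uM (a higher number here means more inhibition at the concentration tested (going by the name of the read-out), a lower number less inhibition), gives -9.7%
- compound 2, `C=C(C)C(=O)N1N=C(c2ccc(-n3ccnc3)cc2)CC1c1ccc(N(C)C)cc1`, in this assay gives 1.6%

For the measured compounds named here, compound 2 stands highest of the two numbers known so far, with compound 1 as its only neighbour, and the gap between them, a number 11.3 percentage points higher from compound 1 to compound 2 (beyond the scatter), lies beyond the scatter though it is modest in size. Both values sit near the zero line, so neither compound shows much inhibition at the concentration tested.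

Compound 3, `CN(C)c1ccc(C2CC(c3ccc(-n4ccnc4)cc3)=NN2C(=O)c2cc(Cl)cc(Cl)c2)cc1`, has not yet been measured in this assay. It differs from compound 2 by 3,5-dichlorophenyl in place of 1-methylethenyl on a carbonyl carbon. Going by the values given here, the only measured step, the one from compound 1 to compound 2, concerns a far smaller exchange at the same carbonyl carbon, and it moved the read-out only modestly. Among the compounds with values here, no measured pair speaks to a 3,5-dichlorophenyl at this position, so the expectation rests on thin ground. Given the modest size of the one known step, compound 3 is expected to move by a number 8.4 percentage points higher from compound 2 to compound 3 (within the scatter), a small rise that may well stay within the scatter. Compound 3 is therefore estimated at 10%, with a range from -10% to 35%.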

Compound 3, a percentage reported as inhibition, at one concentration (the size of the read-out at that concentration, not a potency): 44.5%
Compound 3: the middle estimate sits 34.5 percentage points below what was measured; the measured number lies above the stated range.
By their numbers in this assay, from the lowest: compound 1; then compound 2; then compound 3.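

In this assay, the carbonyl carbon whose other neighbour is the amide-type nitrogen in a ring proves able to carry a large change in the read-out: 3,5-dichlorophenyl in place of 1-methylethenyl gives a number 42.9 percentage points higher from compound 2 to compound 3 (beyond the scatter) and 3,5-dichlorophenyl in place of methyl gives a number 54.2 percentage points higher from compound 1 to compound 3 (beyond the scatter) on the same core. For the compounds shown here, the only earlier step, a number 11.3 percentage points higher from compound 1 to compound 2 (beyond the scatter), exchanged one small open group for another and left both compounds near the zero line, so it gave no sign of how far this position could move the number. Among these three compounds, only compound 3, the one with an aromatic ring on this carbonyl carbon, shows substantial inhibition at the concentration tested, and no measurement at hand accounts for that rise.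

The compounds shown leave open whether the rise belongs to the six-membered aromatic ring or to its two chlorine atoms, a question that a plain phenyl or a cyclohexyl on this carbonyl carbon would help to settle. They also leave open how potent compound 3 is, as its number comes from a single concentration.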